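The source may hold more compounds than are shown below. What is called first, only, known or untested is meant among the compounds shown, and "the series" means these compounds.

Measured compounds:
- Compound 1 `CC1=C(/C=C/C(=O)/C=C/c2ccccc2)C(C)(C)CCC1`: 62200 nM
- Compound 2 `CC1=C(/C=C/C(=O)/C=C/c2ccc(Cl)cc2)C(C)(C)CCC1`: 90600 nM
- Compound 3 `COc1ccccc1/C=C/C(=O)/C=C/C1=C(C)CCCC1(C)C`: 38900 nM

In a functional assay on Hep cells (Homo sapiens) for cytotoxicity, read by sulforhodamine B assay, with a stated time of 48 h (a lower number here means a stronger inhibitor, a higher number a weaker inhibitor), compound 3 gives the lowest of the three numbers; its nearest neighbour is compound 1, separated by a 1.6-fold lower number from compound 1 to compound 3 (0.20 log units; within the scatter), a gap within the scatter, while compound 2 lies further away, beyond the scatter. Compound 4 `CC1=C(/C=C/C(=O)/C=C/c2ccccc2F)C(C)(C)CCC1` is the compound not yet measured. It differs from compound 3 in one place: fluoro in place of methoxy on an aromatic carbon, the fluoro sitting on an aromatic carbon of a six-membered aromatic ring of carbon only, ortho to a large group.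

Within the data shown here, two measured steps bear on this change. Removing the methoxy is the reverse of a 1.6-fold lower number from compound 1 to compound 3 (0.20 log units; within the scatter), within the scatter. Placing a halogen on the same aromatic ring gave a 1.5-fold higher number from compound 1 to compound 2 (0.16 log units; within the scatter), also within the scatter, though the chloro there sits at a different position from the fluoro in compound 4. Both steps are small, so in this assay the expected step is a 1.4-fold higher number from compound 3 to compound 4 (0.15 log units; within the scatter), a slightly higher number, within or near the scatter. Compound 4 is therefore estimated at 55000 nM, with a range from 25000 nM to 120000 nM.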

Compound 4, half-maximal inhibitory concentration: 23600 nM
Estimate against measurement, compound 4: 2.3-fold (0.37 log units) above; the whole stated range lies above it.
By their numbers in this assay, from the lowest: compounds 4, 3, 1 and 2 (each within the scatter of the next, the first and the last beyond it).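

In this assay, among these compounds, fluoro in place of hydrogen on this aromatic carbon, ortho to a large group, gives a 2.6-fold lower number from compound 1 to compound 4 (0.42 log units; beyond the scatter) and is the first single change on this ring to pass beyond the scatter. Fluoro in place of methoxy gives a 1.6-fold lower number from compound 3 to compound 4 (0.22 log units; within the scatter) so these two groups cannot be told apart here, while 2-fluorophenyl in place of 4-chlorophenyl gives a 3.8-fold lower number from compound 2 to compound 4 (0.58 log units; beyond the scatter) with the identity of the halogen and its place changing together. Nothing measured here gives a reason for these steps.

A chloro on this same carbon, or a fluoro where compound 2 carries its chloro, would be needed to separate the halogen from its place. From the compounds shown here alone, how an amine or a carboxylic acid on this carbon would read also remains open.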